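A Methoxypyrimidine in Place of the Benzyl Phenyl

A few compounds are considered here, and "the series" means these few. Any claim that something is new, unique, unknown or untested is made for them only; others in the source may bear on it.

Compound 3 `N#Cc1cnc(NCc2ccccc2)cc1N[C@H]1CC[C@@H](O)CC1` carries a plain phenyl on a saturated chain carbon bound to a nitrogen on an aromatic ring. In an assay on isolated protein for inhibition of protein kinase C theta type (Homo sapiens), read by TR-FRET, with a stated time of 2 h (a higher number here means a weaker inhibitor, a lower number a stronger inhibitor), compound 3 gives 7000 nM, the highest of the three numbers measured. Compound 1 `N#Cc1cnc(NCc2ccccc2C(F)(F)F)cc1N[C@H]1CC[C@@H](O)CC1` differs from it only by a trifluoromethyl on that phenyl, and in this assay compound 1 gives 140 nM; the change from compound 1 to compound 3 is a 50-fold higher number from compound 1 to compound 3 (1.70 log units; beyond the scatter). Within the data shown here, compound 2 `CNC(=O)[C@H]1CC[C@@H](Nc2cc(NCc3cnccc3C(F)(F)F)ncc2C#N)CC1` differs from compound 3 in several places, so no single step links the two. In this assay, among the measured compounds shown here, compound 2 gives 27 nM, and its value shows only that compound 3 is the weakest inhibitor of the three.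

Compound 4 `COc1ncncc1CNc1cc(N[C@H]2CC[C@@H](O)CC2)c(C#N)cn1` is not yet measured. The change from compound 3 to compound 4 is 4-methoxypyrimidin-5-yl in place of phenyl on a saturated chain carbon bound to a nitrogen on an aromatic ring. For the measured compounds named here, no measured step exchanges a phenyl for a substituted heteroaryl, but the step from compound 1 to compound 3 shows how much an unadorned phenyl gives away, so the expectation is that compound 4 recovers part of that loss, with an expected step of a 10-fold lower number from compound 3 to compound 4 (1.00 log units; beyond the scatter). Compound 4 is therefore estimated at 700 nM in this assay, within a range from 150 nM to 3000 nM.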

Compound 4, half-maximal inhibitory concentration: 800 nM
Compound 4: the middle estimate sits 1.1-fold (0.06 log units) below what was measured; the measured number falls inside the stated range.
By their numbers in this assay, from the lowest: compound 2; then compound 1; then compound 4; then compound 3.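

In this assay, 4-methoxypyrimidin-5-yl in place of phenyl gives an 8.8-fold lower number from compound 3 to compound 4 (0.94 log units; beyond the scatter), so this position on a saturated chain carbon bound to a nitrogen on an aromatic ring responds to a change of the ring itself, and not only to the trifluoromethyl that the earlier step, a 50-fold higher number from compound 1 to compound 3 (1.70 log units; beyond the scatter), had picked out. The new ring does not match the trifluoromethyl-bearing phenyl, however, as compound 1 at 140 nM still has a lower number than compound 4 at 800 nM. This change alters the ring atoms and adds a methoxy in one step, and no supporting measurement is available to account for the gain.

The compounds shown leave open whether the ring nitrogens or the methoxy carries the change, which a plain pyrimidin-5-yl or a methoxy-bearing phenyl would separate. As far as these compounds go, it also remains open how this position would respond to a dimethylamino or ethoxy group in place of the methoxy, and whether the methyl amide of compound 2 would lower the number of compound 4 if it replaced the hydroxyl.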